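The compounds below may be only part of what the source reports. "The series", "measured", "known", "first", "only" and "open" are said of these compounds alone.

Working notes on the series. The shared core carries two amino groups and a phenyl group, and the benzyl arm on the ring nitrogen is what varies. Compound 1 `Nc1cc(N)c2nc(-c3ccccc3)c(NCc3ccc(Cl)c(Cl)c3)nc2c1` carries a 3,4-dichlorobenzyl arm; in a functional assay on NCI-H522 cells (Homo sapiens) for inhibition, read by sulforhodamine B assay, with a stated time of 48 h (on this read-out higher numbers stand for weaker inhibition of growth and lower numbers for stronger inhibition of growth), compound 1 gives 2040 nM. Compound 2 `COc1ccc(CNc2nc3cc(N)cc(N)c3nc2-c2ccccc2)cc1OC` carries a 3,4-dimethoxybenzyl arm; in this assay compound 2 gives 2690 nM. The step of a 1.3-fold higher number from compound 1 to compound 2 (0.12 log units; within the scatter). Compound 3 `Nc1cc(N)c2nc(-c3ccccc3)c(NCc3ccc(F)cc3)nc2c1` carries a 4-fluorobenzyl arm. For compound 3 this assay reports only a limit, < 100000 nM, and this is the limit of < 100000 nM in this assay, at which 1 of the 3 values shown sits. Compound 3 therefore stands at a limit and not at a number, so the steps a step that the limit leaves unreadable from compound 1 to compound 3 and a step that the limit leaves unreadable from compound 2 to compound 3 have no readable size.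

Compound 4 `COc1ccc(CNc2nc3cc(N)cc(N)c3nc2-c2ccccc2)cc1` differs from compound 3 by methoxy in place of fluoro on an aromatic carbon. Among the measured compounds shown here, no measured step reads on this change directly; the only step with a number is a 1.3-fold higher number from compound 1 to compound 2 (0.12 log units; within the scatter), and the nearest measured point is compound 2 with its 2690 nM, which carries one methoxy more than compound 4. Compound 4 is estimated at 5000 nM, with a range from 1500 nM to 40000 nM. This expectation corresponds to a step that the limit leaves unreadable from compound 3 to compound 4, readable only as far as the limit of compound 3 allows.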

Compound 4, concentration for 50% growth inhibition: 10000 nM
Compound 4: middle estimate off by 2.0-fold (0.30 log units), on the low side; low and high end bracket the measured number.
By their numbers in this assay, from the lowest: compounds 1 and 2 (each within the scatter of the next); then compound 4.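

With this assay, the arm now gives a readable step beyond the scatter, a 3.7-fold higher number from compound 2 to compound 4 (0.57 log units; beyond the scatter), with hydrogen in place of methoxy on an aromatic carbon, so the second methoxy of compound 2 is not silent here. The comparison with the dichloro arm points the same way: a 4.9-fold higher number from compound 1 to compound 4 (0.69 log units; beyond the scatter), whereas a 1.3-fold higher number from compound 1 to compound 2 (0.12 log units; within the scatter), so among these three compounds only the 4-methoxybenzyl arm stands apart. Compound 3 stands at a limit and not at a number, so none of its steps, including the one to compound 4, can be read: the limit of < 100000 nM in this assay, at which 1 of the 4 values shown sits.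

From the compounds shown here alone, whether 4-fluorobenzyl and 4-methoxybenzyl differ at all therefore stays open. Also open, going by these compounds, is how the series would respond to an amine or a carboxylic acid on the arm's aromatic ring, or to a longer chain in place of the benzyl link.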